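Cytotoxicity notes on the shared core

The source may hold more compounds than are shown below. What is called first, only, known or untested is meant among the compounds shown, and "the series" means these compounds.

Compound 1 `CCCCNc1nc(N)nc2ccn(CC=C(C)C)c12` is examined in an ADME assay on HEK293 cells (Homo sapiens) for cytotoxicity, read by ATP content, with a stated time of 6 h; on this read-out lower numbers stand for higher toxicity in this test and higher numbers for lower toxicity in this test. In this assay compound 1 gives only a limit, > 24000 nM, not a number. Compound 2 `CCCCNc1nc(N)nc2ccn(Cc3cn4ccccc4n3)c12` likewise reaches only a limit in this assay, > 24000 nM. Going by the values given here, compound 1 thus stands at the ceiling of the test, (the limit of > 24000 nM in this assay, at which 2 of the 2 values shown sit), so no order between the two measured compounds can be read, and no step between measured compounds is available.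

Compound 3 `CCCCNc1nc(N)nc2ccn(Cc3ncccc3OC)c12` is not yet measured. It differs from compound 1 in one place: 3-methoxypyridin-2-yl in place of 2-methylprop-1-en-1-yl on a saturated chain carbon bound to an aromatic nitrogen. Among the compounds with values here, with no measured step to lean on, the expectation is that compound 3 also sits at the limit of this assay, with no movement beyond the scatter. The step of a number no higher from compound 1 to compound 3 (the limit leaves the size open) is therefore expected to be none. Compound 3 is expected to give about 24000 nM in this assay, within 12000 nM to 48000 nM, most likely reported again as a limit.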

Compound 3, half-maximal cytotoxic concentration: > 24000 nM
Compound 3 gave a limit, no number; the forecaster's own chance of this, stated with the estimate: 85%; the middle value lies on the limit itself.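

No new step can be read between compound 1 and compound 3 in this assay, because both give only a limit: the limit of > 24000 nM in this assay, at which 3 of the 3 values shown sit.

The compounds shown leave open how far any of the three lies from that limit, and whether exchanging these groups changes cytotoxicity at all.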